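This account rests on a few compounds, and the source may have more. Where it says the series, first, only, none or still open, it means among the compounds named here.

Measured so far:
Compound 1, `O=C(CN(c1nc(Cl)nc2[nH]cnc12)C1CC1)N[C@@H](CO)C(=O)OCc1ccccc1`, gives 34.2% in a functional assay on the whole organism (Tail, strain ICR) with Mus musculus as the target, in the tail flick test, with a stated time of 60 min, at a dose of 25 umol/kg by the oral route; a higher number here means a stronger effect of the compound at the dose given, a lower number a weaker effect.
Compound 2, `O=C(O)[C@@H]1CCCN1C(=O)CN(c1nc(Cl)nc2[nH]cnc12)C1CC1`, gives 34.9% in this assay.

On these two numbers compound 1 stands lowest, and compound 2 lies so close to it that the two read alike. Compound 3 is `N=C(N)NCCC[C@H](NC(=O)CN(c1nc(Cl)nc2[nH]cnc12)C1CC1)C(=O)OCc1ccccc1`; it differs from compound 1 in the way that follows (a group of 6 heavy atoms (3 carbon, 3 nitrogen; no ring) in place of one oxygen atom, on a saturated chain carbon, two bonds along the chain from an amide-type nitrogen and a carbonyl carbon). Among the measured compounds shown here, no comparable step between measured compounds exists, so there is no guide to its size; the expected step of a number 0.8 percentage points higher from compound 1 to compound 3 (within the scatter) is small, with no direction beyond the scatter. For compound 3 the expected activity is 35%, in a range from 15% to 60%.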

Compound 3, a percentage reported as activity, at one dose (the size of the read-out at that dose, not a potency): 30.6%
The estimate for compound 3 lay 4.4 percentage points above the measured number, and the stated range covers the measured number.
By their numbers in this assay, from the lowest: compounds 3, 1 and 2 (each within the scatter of the next).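

On this saturated chain carbon, two bonds along the chain from an amide-type nitrogen and a carbonyl carbon, replacing the hydroxy with a group of 6 heavy atoms gives in this assay a step of a number 3.6 percentage points lower from compound 1 to compound 3 (within the scatter) between the two compounds. A much larger entering group, with more hydrogen-bond donors, therefore still leaves the two compounds reading alike at this one dose. Nothing measured here explains this.

Going by these compounds, whether a methyl group or a primary amine at this place would also read alike stays open. A single dose also leaves the potency of these compounds unknown.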